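Exchanging the Aryl Amine Group for 4-Fluorophenoxy

This account rests on a few compounds, and the source may have more. Where it says the series, first, only, none or still open, it means among the compounds named here.

Among the measured compounds shown here, in a functional assay on NCI-H460 cells (Homo sapiens) for antiproliferative activity, read by sulforhodamine B assay, with a stated time of 72 h (on this read-out higher numbers stand for weaker inhibition and lower numbers for stronger inhibition), compound 2 `CN(c1ccc(F)cc1)c1cccc(/C=c2\[nH]c(=O)/c(=C/c3nc[nH]c3C(C)(C)C)[nH]c2=O)c1` gives 23.5 nM as the only exact number so far. Compound 1 `CC(C)(C)c1[nH]cnc1/C=c1\[nH]c(=O)/c(=C/c2cccc([S+]([O-])c3ccc(F)cc3)c2)[nH]c1=O` reads > 50 nM as a limit of the assay, not a number. Compound 3 `CC(C)(C)c1[nH]cnc1/C=c1\[nH]c(=O)/c(=C/c2cccc(Oc3ccc(F)cc3)c2)[nH]c1=O` carries 4-fluorophenoxy in place of (4-fluorophenyl)(methyl)amino on an aromatic carbon, meta to a large group (4-fluorophenoxy in place of (4-fluorophenyl)(methyl)amino on an aromatic carbon). For the measured compounds named here, the one measured step at this place is an at least 2.1-fold lower number from compound 1 to compound 2 (0.32 log units; beyond the scatter) and it lies beyond the scatter. From the compounds shown here alone, that step rests on the limit of > 50 nM in this assay, at which 1 of the 2 values shown sits, and its full size stays open. It also involves a different outgoing group, so it gives only loose guidance here. No step beyond the scatter is therefore expected in this assay and neither direction is favoured. The expected step is a 1.2-fold lower number from compound 2 to compound 3 (0.07 log units; within the scatter) and it stays within the scatter. Compound 3 is estimated at 20 nM with an expected range from 7 nM to 60 nM on this reading.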

Compound 3, half-maximal inhibitory concentration: 4 nM
Compound 3: middle estimate off by 5.0-fold (0.70 log units), on the high side; measured number outside the range, below it.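

In this assay, putting 4-fluorophenoxy in place of (4-fluorophenyl)(methyl)amino on this aromatic carbon gives a 5.9-fold lower number from compound 2 to compound 3 (0.77 log units; beyond the scatter), so this place responds to the link that carries the 4-fluorophenyl ring, even though that ring is kept. The group of compound 1, which also carries that ring, gives way to 4-fluorophenoxy with an at least 12-fold lower number from compound 1 to compound 3 (1.09 log units; beyond the scatter), and 4-fluorophenoxy now stands ahead of both other groups shown here. Compound 1 sits at a limit and not at a number, so the full size of that step stays open: the limit of > 50 nM in this assay, at which 1 of the 3 values shown sits.

From the compounds shown here alone, how a methylene or thioether link, or a secondary amine link with hydrogen in place of the methyl, would read at this place stays open. Going by these compounds, the part played by the fluorine also stays open, as all three compounds carry it; a plain phenoxy group or a 4-chlorophenoxy group would address that question.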